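A few compounds are considered here, and "the series" means these few. Any claim that something is new, unique, unknown or untested is made for them only; others in the source may bear on it.

Measured so far in a functional assay on MCF7 cells (Homo sapiens) for antiproliferative activity, read by MTT assay; on this read-out lower numbers stand for stronger inhibition and higher numbers for weaker inhibition:
Compound 1 `CCCCC/C=C\C/C=C\CCCCCCCc1cc(=O)c2c(O)cc(O)c(C)c2o1`: 17500 nM
Compound 2 `CCCCC/C=C\C/C=C\CCCCCCCc1cc(=O)c2c(O)c(C)c(O)cc2o1`: > 84100 nM (a limit, not a number)
Compound 3 `CCCCCCCCCCCCCCCc1cc(=O)c2c(O)c(C)c(O)cc2o1`: 43200 nM

Compound 2 gives no number, only a limit: the limit of > 84100 nM in this assay, at which 1 of the 3 values shown sits. Compound 4 `CCCCC/C=C\C/C=C\CCCCCCCc1cc(=O)c2c(O)cc(O)cc2o1` keeps the chain of compound 2 and differs from it by one change, hydrogen in place of methyl on an aromatic carbon.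

Among the compounds with values here, no measured step covers this change. Within the data shown here, the only measured step, an at least 1.9-fold lower number from compound 2 to compound 3 (0.28 log units; that floor lies within the scatter), lies in the chain rather than at the methyl, and its floor lies within the scatter, so it gives no size for the change at hand. The remaining guide is the range of the numeric readings, with compound 1 at 17500 nM and compound 3 at 43200 nM. A reading for compound 4 is expected within or near that range in this assay, which would mean a lower number than the limit of compound 2, although compound 4 may well end at a limit too. The estimated step is an at least 1.8-fold lower number from compound 2 to compound 4 (0.27 log units; that floor lies within the scatter). For compound 4 the estimate is 45000 nM, with an expected range from 17000 nM to 110000 nM.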

Compound 4, half-maximal inhibitory concentration: 17500 nM
Beside the measured number, compound 4's estimate is 2.6-fold (0.41 log units) above it, and the stated range covers the measured number.
By their numbers in this assay, from the lowest: compounds 1 and 4 (each within the scatter of the next); then compound 3. At a limit, above all of these: compound 2.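

In this assay, within the data shown here, hydrogen in place of methyl on the aromatic carbon ortho to two hydroxy groups gives an at least 4.8-fold lower number from compound 2 to compound 4 (0.68 log units; beyond the scatter), so the earlier compounds' open question about this methyl now has a direction and a minimum size, and with the long unsaturated chain held fixed, the methyl at this place goes with the weaker reading. The same exchange with the methyl of compound 1, which stands on a different aromatic carbon of the core, gives no change at the digits printed from compound 1 to compound 4 (within the scatter), so the methyl matters at one carbon and shows no measurable effect at the other. The step at this position is only a floor, for compound 2 gives a limit and not a number: the limit of > 84100 nM in this assay, at which 1 of the 4 values shown sits.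

Going by these compounds, how large the step truly is stays open, and so does whether it holds with the saturated chain of compound 3, which has no partner here carrying hydrogen at this place. The compounds shown also do not tell whether an ethyl group, a methoxy group or a chlorine atom on this carbon would read like methyl or like hydrogen.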